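The source may report more compounds than this note shows. Statements on the series, on what has been measured and on what is new or still open speak of the compounds shown alone.

Compound 1 `CC(C)(C)c1ccc(N(C(=O)c2ccco2)C(C(=O)NC2CCCC2)c2cccnc2)cc1` gives 101000 nM in a toxicity assay on Vero C1008 cells (Chlorocebus sabaeus) for cytotoxicity, read by neutral red uptake, with a stated time of 5 days; on this read-out lower numbers stand for higher toxicity in this test and higher numbers for lower toxicity in this test.
Compound 2 `C[C@H](NC(=O)C(c1cccnc1)N(C(=O)c1ccco1)c1ccc([Si](C)(C)C)cc1)c1ccccc1` gives 19400 nM in this assay.
Compound 3 `C[C@H](NC(=O)C(c1cccnc1)N(C(=O)c1ccco1)c1ccc(C2CCCCC2)cc1)c1ccccc1` gives 9610 nM in this assay.

Among these three, compound 3 stands lowest in this assay, with compound 2 nearest and compound 1 furthest; both gaps are beyond the scatter. Among the compounds with values here, the one comparison within this set that alters the same position is a 2.0-fold lower number from compound 2 to compound 3 (0.31 log units; beyond the scatter), a modest shift toward a lower number.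

Compound 4 `C[C@H](NC(=O)C(c1cccnc1)N(C(=O)c1ccco1)c1ccc(-c2ccco2)cc1)c1ccccc1` is not yet measured in this assay. It differs from compound 3 only in that (furan-2-yl in place of cyclohexyl on an aromatic carbon). Within the data shown here, no measured pair shows this particular exchange, so the step from compound 2 to compound 3 is the sole guide, and it speaks only to how much this position can move the number, not to which way a furan-2-yl ring would move it. Among the measured compounds shown here, the one step at this position was modest. Compound 4 is therefore expected to land near compound 3 or somewhat higher, the expected step being a 1.6-fold higher number from compound 3 to compound 4 (0.19 log units; within the scatter), of a size around the edge of the scatter. The estimate for compound 4 in this assay is 15000 nM, within a range from 6000 nM to 40000 nM.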

Compound 4, half-maximal cytotoxic concentration: 56400 nM
The estimate for compound 4 lay 3.8-fold (0.58 log units) below the measured number; the measured number lies above the stated range.
By their numbers in this assay, from the lowest: compound 3; then compound 2; then compounds 4 and 1 (each within the scatter of the next).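

In this assay, the position on the aromatic carbon para to a large group proves able to move the number upward as well as downward: the change from cyclohexyl to furan-2-yl gives a 5.9-fold higher number from compound 3 to compound 4 (0.77 log units; beyond the scatter), a larger shift than the earlier 2.0-fold lower number from compound 2 to compound 3 (0.31 log units; beyond the scatter) at the same place. Measured against the group of 3 carbon and 1 silicon, furan-2-yl also gives a 2.9-fold higher number from compound 2 to compound 4 (0.46 log units; beyond the scatter), so compound 4 stands highest among the three compounds that differ only at this position, and the two ring-bearing groups, cyclohexyl and furan-2-yl, lie on opposite sides of the silicon group. No measurement given here accounts for this order.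

Furan-2-yl differs from cyclohexyl at once in ring size, in being aromatic and in carrying an oxygen, and these compounds cannot separate those differences. On these data alone, a phenyl ring or a tetrahydrofuran-2-yl ring at this position would help to show whether the higher number goes with the aromatic ring or with the oxygen, and that question stays open here.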